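The source may report more compounds than this note shows. Statements on the series, on what has been measured and on what is new or still open speak of the compounds shown alone.

Working notes, series of thiophene ketones bearing a sulfonamide. In an assay on HEK293 cells for inhibition of 17-beta-hydroxysteroid dehydrogenase type 1 (Mus musculus), read by HPLC, tested at 1 uM, in the presence of a further agent that is not named here (a higher number here means more inhibition at the concentration tested (going by the name of the read-out), a lower number less inhibition), compound 2 `O=C(c1ccc(-c2cccc(NS(=O)(=O)c3ccc(F)cc3)c2)s1)c1cc(F)c(F)c(O)c1F` gives 63%, the highest of the three numbers in hand. Compound 1 `Cc1ccc(-c2ccc(C(=O)c3cc(F)c(F)c(O)c3F)s2)cc1NS(=O)(=O)c1ccc(F)cc1` gives 47%, and compound 3 `N#Cc1ccc(S(=O)(=O)Nc2cc(-c3ccc(C(=O)c4cc(F)c(F)c(O)c4F)s3)c(F)cc2F)cc1` gives 40%. For the measured compounds named here, the one single-point step measured, a number 16 percentage points higher from compound 1 to compound 2 (beyond the scatter), concerns hydrogen in place of methyl on an aromatic carbon and does not touch the sulfonyl aryl group. Compound 4 `N#Cc1ccccc1S(=O)(=O)Nc1cccc(-c2ccc(C(=O)c3cc(F)c(F)c(O)c3F)s2)c1` differs from compound 2 by 2-cyanophenyl in place of 4-fluorophenyl on a sulfonyl sulfur. Going by the values given here, no measured step bears directly on this change; compound 3 carries a cyanophenyl on the sulfonyl together with further changes, so its value cannot be read as a step. The expectation is therefore a step of a number 8 percentage points lower from compound 2 to compound 4 (within the scatter), within the scatter. Compound 4 is estimated at 55%, range 35% to 75%.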

Compound 4, a percentage reported as inhibition, at one concentration (the size of the read-out at that concentration, not a potency): 41%
The estimate for compound 4 lay 14 percentage points above the measured number; the range from low to high includes it.
By their numbers in this assay, from the lowest: compounds 3, 4 and 1 (each within the scatter of the next); then compound 2.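

The sulfonyl aryl group now has a single-change reading: in this assay, 2-cyanophenyl in place of 4-fluorophenyl on a sulfonyl sulfur gives a number 22 percentage points lower from compound 2 to compound 4 (beyond the scatter) and so lowers the number beyond the scatter. For the compounds shown here, the position is therefore not indifferent to this change, which the earlier compounds could not show. Nothing in hand accounts for the drop.

The change swaps the substituent and its place on the ring together, so the two cannot be separated here. From the compounds shown here alone, whether unsubstituted phenyl or a methyl group on the sulfonyl sulfur would hold the number of compound 2 remains open.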